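Benzyl for dichlorophenyl on the sulfonyl of compound 1

The source may report more compounds than this note shows. Statements on the series, on what has been measured and on what is new or still open speak of the compounds shown alone.

Going by the values given here, compound 1 `Cc1csc2c(N[C@@H](C)CN3CCN(S(=O)(=O)c4ccc(Cl)c(Cl)c4)CC3)ncnc12` gives 17 nM in a functional assay on RH7777 cells for antagonist activity at lysophosphatidic acid receptor 2 (Homo sapiens), read by calcium flux (on this read-out lower numbers stand for stronger inhibition and higher numbers for weaker inhibition), and is the only compound here with a number rather than a limit. Compound 2 `COc1ccccc1N1CCN(CCNc2nc(C(F)(F)F)nc3ccccc23)CC1`, built on a different core and a different side chain, reaches only a limit of the assay, > 30000 nM in this assay; the relevant point is the limit of > 30000 nM in this assay, at which 1 of the 2 values shown sits. Among the compounds with values here, no pair of measured compounds differs in a single place, so no measured step is available and compound 1 stands alone as the reference.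

Compound 3 `Cc1csc2c(N[C@@H](C)CN3CCN(S(=O)(=O)Cc4ccccc4)CC3)ncnc12` differs from compound 1 by benzyl in place of 3,4-dichlorophenyl on a sulfonyl sulfur: benzyl in place of 3,4-dichlorophenyl on the sulfonyl sulfur, whose other neighbour is the sulfonamide nitrogen in the ring. The rest of the molecule is kept. The expected step is an 8.8-fold higher number from compound 1 to compound 3 (0.95 log units; beyond the scatter), a loss of activity beyond the usual scatter, with a smaller chance of an outcome near compound 1. The estimate for compound 3 in this assay is 150 nM, expected to fall between 30 nM and 1000 nM.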

Compound 3, half-maximal inhibitory concentration: 1860 nM
For compound 3 the middle estimate is 12-fold (1.09 log units) below the measured one; the measured number lies above the stated range.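

Going by these compounds alone, on the sulfonyl sulfur of the core of compound 1, the exchange of 3,4-dichlorophenyl for benzyl gives the first single-place step in this assay: a 110-fold higher number from compound 1 to compound 3 (2.04 log units; beyond the scatter), so this position is sensitive to the exchange. The two groups share one six-membered aromatic ring of carbon only and neither has a hydrogen-bond donor or acceptor, so these shared features do not preserve activity, although compound 3 still gives a number, 1860 nM, and not a limit. No measurement shown here bears on the reason for the size of this step.

Benzyl differs from 3,4-dichlorophenyl both in the added carbon on the sulfonyl sulfur and in the loss of the two chlorines, and the compounds shown do not separate these two changes. Plain phenyl and 3,4-dichlorobenzyl on the same sulfur would part them, while a 4-chlorophenyl or 3-chlorophenyl group would show whether either chlorine alone carries the difference.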